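The compounds below may be only part of what the source reports. "The series", "measured", "known", "first", "only" and "open" are said of these compounds alone.

- compound 1 `Cn1cnc(C(=O)N(Cc2ccc(F)c(C(F)(F)F)c2)[C@H]2C[C@H]3CNC[C@H]3C2)c1`: > 2 h (a limit of the assay)
- compound 2 `COc1ccc(CN(C(=O)c2cn(C)cn2)[C@H]2C[C@H]3CNC[C@H]3C2)cc1OC1CCCC1`: > 2 h (a limit of the assay)

In an in vitro ADME assay on microsomes (Homo sapiens) for metabolic stability (a higher number here means that the compound lasts longer, a lower number that the compound disappears faster), compound 1 gives > 2 h, which is a limit and not a number. Among the compounds with values here, compound 2 is also reported only as a limit, and the series so far reads (the limit of > 2 h in this assay, at which 2 of the 2 values shown sit). No measured half-life is therefore available for either compound.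

Compound 3 `Cn1cnc(C(=O)N(Cc2ccc(F)c(C(F)(F)F)c2)[C@@H]2C[C@H]3CNC[C@H]3C2)c1` is the next to be read against compound 1: the two compounds have the same atoms and bonds and differ only in configuration as drawn: 1 of 3 stereo elements differ; a stereocentre at a saturated ring carbon is drawn r in compound 1 and s in compound 3. Within the data shown here, no measured pair shows what a change of configuration does in this assay. The expectation for compound 3 rests on compound 1, whose > 2 h is a limit. The estimated step that the limit leaves unreadable from compound 1 to compound 3 is expected to stay within the usual scatter, with no direction favoured. Compound 3 is expected at 3 h, with an estimated range of 1.5 h to 6 h.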

Compound 3, half-life: > 2 h
Compound 3 gave a limit, no number (the forecaster's own chance of this, stated with the estimate: 70%); the middle value lies beyond the limit too.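

No step can be read between compound 1 and compound 3 in this assay, as both values are limits and not numbers: the limit of > 2 h in this assay, at which 3 of the 3 values shown sit.

The compounds shown leave open how long any of them lasts beyond that limit, and whether the change of configuration alters the half-life at all.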